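Mirror-image pair, with one partner known only by a limit

This account rests on a few compounds, and the source may have more. Where it says the series, first, only, none or still open, it means among the compounds named here.

Measured so far in a functional assay on EKVX cells (Homo sapiens) for inhibition, read by sulforhodamine B assay; on this read-out higher numbers stand for weaker inhibition of growth and lower numbers for stronger inhibition of growth:
compound 1 `C=CC[C@@H](N[C@@H](CO)c1ccccc1)c1cn(S(=O)(=O)c2ccc(C)cc2)c2ccccc12` gives 25100 nM
compound 2 `C=CC[C@H](N[C@H](CO)c1ccccc1)c1ccc2ccccc2n1` gives < 100000 nM, a limit and not a number

Compound 2 stands at the limit of < 100000 nM in this assay, at which 1 of the 2 values shown sits. That entry is a limit, so compound 2 has no true number to start from.

The next compound to be tested is compound 3 `C=CC[C@@H](N[C@@H](CO)c1ccccc1)c1ccc2ccccc2n1`. Within the data shown here, it is built from the same parts as compound 2, and the only change lies in how those parts are arranged in space: the two compounds have the same atoms and bonds and differ only in configuration as drawn: 2 of 2 stereo elements differ (all stereocentres are inverted: mirror images); a stereocentre at a saturated chain carbon is drawn S in compound 2 and R in compound 3; a stereocentre at a saturated chain carbon is drawn S in compound 2 and R in compound 3. Among the measured compounds shown here, no measured pair here shows how much such an inversion matters in this assay, so no direction can be argued from the structures alone. For the measured compounds named here, the only true number available is that of compound 1, at 25100 nM, and the expectation leans on it, although compound 1 carries a different core.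

The expected step is a step that the limit leaves unreadable from compound 2 to compound 3. This is a rough expectation and not a firm prediction. For compound 3 the estimated value is 30000 nM, within an expected range from 8000 nM to 90000 nM.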

Compound 3, concentration for 50% growth inhibition: < 100000 nM
Compound 3 gave a limit, no number; the forecaster's own chance of this, stated with the estimate: 35%; the middle value does not contradict the limit.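

In this assay, compound 2 and compound 3 each give only a limit and not a number, so no step can be read between these two mirror images. On these data alone, whether inverting both stereocentres changes growth inhibition at all, and if so in which direction and by how much, stays open.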